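The source may report more compounds than this note shows. Statements on the series, on what has been measured and on what is new or still open speak of the compounds shown alone.

Measured so far:
Compound 1, `COc1ccc(-n2ccnc2SCC(=O)Nc2ccccc2C)cc1`. In an ADME assay on MT4 cells (Homo sapiens) for cytotoxicity, read by MTT assay (a lower number here means that less compound is tolerated, a higher number that more compound is tolerated), compound 1 gives > 353000 nM, which is a limit of the assay rather than a number.
Compound 2, `Cc1ccc(-n2ccnc2SCC(=O)Nc2ccccc2[N+](=O)[O-])cc1`. In this assay compound 2 gives 131000 nM.
Compound 3, `O=C(CSc1nccn1-c1cccc2ccccc12)Nc1ccccc1[N+](=O)[O-]`. In this assay compound 3 gives 28800 nM.

Of the two plain numbers, compound 2 stands highest; compound 3 lies nearest, with a lower number that falls beyond the scatter. Compound 1 sits at the limit of > 353000 nM in this assay, at which 1 of the 3 values shown sits.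

Compound 4, `Cc1ccc(-n2ccnc2SCC(=O)Nc2ccccc2Br)cc1`, differs from compound 2 by bromo in place of nitro on an aromatic carbon. Among the measured compounds shown here, no measured pair isolates this change, so there is no step to lean on. The expected step is a 1.1-fold lower number from compound 2 to compound 4 (0.04 log units; within the scatter), a shift within the scatter rather than beyond it. Compound 4 is therefore estimated at 120000 nM, with a range from 40000 nM to 350000 nM.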

Compound 4, half-maximal cytotoxic concentration: 39300 nM
For compound 4 the middle estimate is 3.1-fold (0.48 log units) above the measured one; the measured number lies below the stated range.
By their numbers in this assay, from the lowest: compounds 3 and 4 (each within the scatter of the next); then compound 2. At a limit, above all of these: compound 1.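

In this assay the aromatic carbon ortho to a large group proves sensitive to what it carries: bromo in place of nitro gives a 3.3-fold lower number from compound 2 to compound 4 (0.52 log units; beyond the scatter). This is the first exchange among these compounds that isolates a single place, and it rests on one pair alone. Nothing measured here accounts for the size of this step. The compounds shown leave open how an amine or a carboxylic acid at this position would compare, and whether the same exchange gives a similar step on the core of compound 3.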